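A few compounds are considered here, and "the series" means these few. Any claim that something is new, unique, unknown or untested is made for them only; others in the source may bear on it.

Compound 1 `C=CC1=C(C(=O)NCCC)C(c2ccc(Cl)c(Cl)c2)OC1` and compound 2 `C=CC1=C(C(=O)NCC(C)C)C(c2ccc(Cl)c(Cl)c2)OC1` share one core, while compound 3 `C=CC1=C(C(=O)NCCC)C(c2ccc(OC)cc2)OC1` carries another; the difference between the two cores is not broken down here. In a functional assay on SW480 cells (Homo sapiens) for cytotoxicity, read by MTT assay, with a stated time of 24 h (a lower number here means a stronger inhibitor, a higher number a weaker inhibitor), compound 1 reaches only the limit > 100000 nM. Compound 2 likewise reaches only the limit > 100000 nM in this assay. Compound 3 too reaches only the limit > 100000 nM in this assay. The change methyl in place of hydrogen on a saturated chain carbon bound to two saturated chain carbons thus gave a step that the two limits leave unreadable from compound 1 to compound 2, as the limit of > 100000 nM in this assay, at which 3 of the 3 values shown sit, shows. Compound 4 `C=CC1=C(C(=O)NCC(C)C)C(c2ccc(OC)cc2)OC1` carries the same change, (methyl in place of hydrogen on a saturated chain carbon bound to two saturated chain carbons), on the core of compound 3. With every value sitting at the limit of > 100000 nM in this assay, at which 3 of the 3 values shown sit, compound 4 is expected to give about 150000 nM in this assay, most probably again as a limit rather than a number. That estimate corresponds to an expected step that the limit leaves unreadable from compound 3 to compound 4.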

Compound 4, half-maximal inhibitory concentration: > 100000 nM
Compound 4: a limit, no number; the forecaster's own chance of this, stated with the estimate: 85%; the middle value is on the limit's open side.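

Compound 3 and compound 4 both give only limits in this assay and no step can be read between them. The compounds shown leave open how strongly each acts and what methyl in place of hydrogen does on either core, with all of them resting on one limit: the limit of > 100000 nM in this assay, at which 4 of the 4 values shown sit.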